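This account rests on a few compounds, and the source may have more. Where it says the series, first, only, none or still open, it means among the compounds named here.

Of the compounds shown here, three sharing one core have been measured so far. Compound 1 `O=C(COc1ccc2c(=O)ccoc2c1)Nc1cccc(NC(=O)c2ccc(OC(F)(F)F)cc2)c1` gives 869 nM in an assay on isolated protein for inhibition of Rho-associated protein kinase 1 (Homo sapiens), read by scintillation counting, radiometric assay and 33P incorporation, with a stated time of 40 min, in the presence of a further agent that is not named here; a higher number here means a weaker inhibitor, a lower number a stronger inhibitor. Compound 2 `O=C(COc1ccc2c(=O)ccoc2c1)Nc1cccc(NC(=O)c2cccc([N+](=O)[O-])c2)c1` gives 528 nM in this assay, and compound 3 `Cc1cc(C(=O)Nc2cccc(NC(=O)COc3ccc4c(=O)ccoc4c3)c2)ccc1C(F)(F)F` gives 460 nM in this assay. The number for compound 3 is the smallest of the three, but the gap to compound 2 and the gap to compound 1 are each within the scatter, so the three compounds cannot be told apart on these numbers.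

Compound 4 `Cc1cc(C(=O)Nc2cccc(NC(=O)COc3ccc4c(=O)ccoc4c3)c2)no1` differs from compound 3 in one place: a group of 6 heavy atoms (4 carbon, 1 nitrogen, 1 oxygen; one five-membered aromatic ring with 2 hetero atoms) in place of a group of 11 heavy atoms (8 carbon, 3 fluorine; one six-membered aromatic ring of carbon only), on a carbonyl carbon. The measured steps all change the same aryl group on that carbonyl carbon: a 1.6-fold lower number from compound 1 to compound 2 (0.22 log units; within the scatter), a 1.9-fold lower number from compound 1 to compound 3 (0.28 log units; within the scatter) and a 1.1-fold lower number from compound 2 to compound 3 (0.06 log units; within the scatter). Each of them swaps substituents on a six-membered carbon ring and each stays within the scatter, which suggests this position tolerates such swaps. None of them replaces the six-membered ring by a five-membered heteroaromatic ring, so the change to compound 4 reaches beyond what the data cover. The expectation is therefore a step of a 2.0-fold higher number from compound 3 to compound 4 (0.29 log units; within the scatter) that is small, with a wide range to allow for the unfamiliar ring. Compound 4 is estimated at 900 nM, expected to lie between 300 nM and 3000 nM.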

Compound 4, half-maximal inhibitory concentration: 68 nM
Estimate against measurement, compound 4: 13-fold (1.12 log units) above; measured number outside the range, below it.
By their numbers in this assay, from the lowest: compound 4; then compounds 3, 2 and 1 (each within the scatter of the next).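

The three substituted phenyl groups on this carbonyl carbon stayed within the scatter of one another in this assay, but 5-methyl-1,2-oxazol-3-yl moves the number beyond the scatter against each of them (a 6.8-fold lower number from compound 3 to compound 4 (0.83 log units; beyond the scatter) and a 7.8-fold lower number from compound 2 to compound 4 (0.89 log units; beyond the scatter) and a 13-fold lower number from compound 1 to compound 4 (1.11 log units; beyond the scatter)). For the compounds shown here, the position is therefore less forgiving than the earlier compounds suggested: what it tolerated was a swap of substituents on a six-membered carbon ring, whereas a change of the ring itself gives a clearly stronger inhibitor. The ring size, the hetero atoms and the substituents all change together in this step, and nothing measured here accounts for the result.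

Only one five-membered ring is shown, so it remains open whether the gain belongs to the ring or depends on its methyl group, which a 1,2-oxazol-3-yl without that methyl would test. An unsubstituted phenyl on the same carbonyl carbon would also show how much of the difference comes from the substituents on the six-membered rings rather than from the ring itself.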